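Fluoro Exchanged for Cyclopropylaminomethyl on the Shared Core

A few compounds are considered here, and "the series" means these few. Any claim that something is new, unique, unknown or untested is made for them only; others in the source may bear on it.

Compound 1 `Cn1nc2c(=O)n(CC3(O)CCN(Cc4ccc(-c5ccco5)cc4Cl)CC3)cnc2c1-c1ccc(OC(F)F)cc1` — 179 nM in an assay on isolated protein for inhibition of ubiquitin carboxyl-terminal hydrolase 7 (Homo sapiens), with stated times of 30 min and 2 h; on this read-out lower numbers stand for stronger inhibition and higher numbers for weaker inhibition
Compound 2 `Cn1nc2c(=O)n(CC3(O)CCN(Cc4ccc(-c5ccco5)cc4Cl)CC3)cnc2c1-c1ccc(F)cc1` — 64.5 nM

Within the data shown here, compound 2 holds the lower of the two numbers so far measured, and the only other value, that of compound 1, lies beyond the scatter: a 2.8-fold lower number from compound 1 to compound 2 (0.44 log units; beyond the scatter). Compound 3 `Cn1nc2c(=O)n(CC3(O)CCN(Cc4ccc(-c5ccco5)cc4Cl)CC3)cnc2c1-c1ccc(CNC2CC2)cc1` is the next member, and it departs from compound 2 by (cyclopropylamino)methyl in place of fluoro on an aromatic carbon.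

Among the measured compounds shown here, only one measured step bears on this change. It touched the same aromatic carbon, but there the exchange was between fluoro and difluoromethoxy, two groups without a hydrogen-bond donor, and it gave a modest move. For the measured compounds named here, the group now entering is larger and brings a donor and an acceptor, so the earlier step is an imperfect guide, and the data contain no example of such a group at this place.

On this basis the change from compound 2 to compound 3 is expected to give a 1.9-fold higher number from compound 2 to compound 3 (0.27 log units; within the scatter) in this assay, a step that need not exceed the scatter. Compound 3 is therefore estimated at 120 nM, within a range from 40 nM to 400 nM.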

Compound 3, half-maximal inhibitory concentration: 54.1 nM
Compound 3: middle estimate off by 2.2-fold (0.35 log units), on the high side, and the stated range covers the measured number.
By their numbers in this assay, from the lowest: compounds 3 and 2 (each within the scatter of the next); then compound 1.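

The aromatic carbon para to a large group accepts a much larger substituent than the earlier pair had shown: in this assay, (cyclopropylamino)methyl, with its three-membered ring, hydrogen-bond donor and hydrogen-bond acceptor, replaces the single fluorine atom with a 1.2-fold lower number from compound 2 to compound 3 (0.08 log units; within the scatter), leaving compound 2 and compound 3 indistinguishable on this read-out. Measured against difluoromethoxy, the same group gives a 3.3-fold lower number from compound 1 to compound 3 (0.52 log units; beyond the scatter), so two very different groups, fluoro and (cyclopropylamino)methyl, now both stand apart from difluoromethoxy by a modest margin. No measurement shown here accounts for this outcome.

The compounds shown do not separate the contributions of the nitrogen and the cyclopropyl ring within the entering group, a question that a plain aminomethyl group or a cyclopropylmethyl group at the same carbon would address. Among these compounds, they also leave open how a carboxylic acid, a morpholine ring or a longer amine chain would fare at this place, and whether the tolerance seen here extends beyond the single entering group tested on this core.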